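The compounds below may be only part of what the source reports. "The series", "measured", "known", "first", "only" and "open" are said of these compounds alone.

In a functional assay on HEL cells (Homo sapiens) (a higher number here means that more compound is tolerated, a lower number that less compound is tolerated), compound 3 (`Cc1cn([C@@H]2O[C@H](CO[Si](C)(C)C(C)(C)C)[C@@]3(OS(=O)(=O)C=C3NCCC(=O)O)[C@H]2O[Si](C)(C)C(C)(C)C)c(=O)n(C)c1=O`) gives 34000 nM, the second highest of three numbers. Compound 2 (`Cc1cn([C@@H]2O[C@H](CO[Si](C)(C)C(C)(C)C)[C@@]3(OS(=O)(=O)C=C3NC(=O)c3ccccc3)[C@H]2O[Si](C)(C)C(C)(C)C)c(=O)n(C)c1=O`) gives 9700 nM, and compound 1 (`COC(=O)CNC1=CS(=O)(=O)O[C@@]12[C@@H](CO[Si](C)(C)C(C)(C)C)O[C@@H](n1cc(C)c(=O)n(C)c1=O)[C@@H]2O[Si](C)(C)C(C)(C)C`) gives 160000 nM. Compound 4 (`COC(=O)CCNC1=CS(=O)(=O)O[C@@]12[C@@H](CO[Si](C)(C)C(C)(C)C)O[C@@H](n1cc(C)c(=O)n(C)c1=O)[C@@H]2O[Si](C)(C)C(C)(C)C`) carries methyl in place of hydrogen on an oxygen next to a carbonyl group. Among the measured compounds shown here, no measured step isolates this change. The closest is a 4.7-fold lower number from compound 1 to compound 3 (0.67 log units; beyond the scatter), where carboxymethyl replaces methoxycarbonyl, so the new change runs roughly the opposite way. The step of a 3.5-fold higher number from compound 2 to compound 3 (0.54 log units; beyond the scatter) swaps benzoyl and bears on it less. A modest rise, no larger than the first of these, is therefore expected in this assay. The expected size is a 2.1-fold higher number from compound 3 to compound 4 (0.31 log units; beyond the scatter). For compound 4 the estimated value is 70000 nM, with an expected range from 25000 nM to 180000 nM.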

Compound 4, half-maximal cytotoxic concentration: 94000 nM
Compound 4: the middle estimate sits 1.3-fold (0.13 log units) below what was measured, within the range that was stated.
By their numbers in this assay, from the lowest: compound 2; then compound 3; then compounds 4 and 1 (each within the scatter of the next).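

In this assay, among the compounds shown here, the first direct reading of carboxy to methoxycarbonyl on the chain is a 2.8-fold higher number from compound 3 to compound 4 (0.44 log units; beyond the scatter) and it lies beyond the scatter. The ester chain of compound 4 also separates clearly from the benzoyl group, with a 9.7-fold higher number from compound 2 to compound 4 (0.99 log units; beyond the scatter), whereas a 1.7-fold lower number from compound 1 to compound 4 (0.23 log units; within the scatter) stays within the scatter, so 2-(methoxycarbonyl)ethyl and (methoxycarbonyl)methyl on the amine nitrogen are not told apart. No evidence accounts for these differences.

As far as these compounds go, whether an ethyl ester or a primary amide at this oxygen-bearing carbonyl would behave like the methyl ester remains open. So does whether a longer chain carrying methoxycarbonyl would still stay near these two esters.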